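This account rests on a few compounds, and the source may have more. Where it says the series, first, only, none or still open, it means among the compounds named here.

Measured so far, in a functional assay on HCT-116 cells (Homo sapiens) for cytotoxicity, read by MTT assay, with a stated time of 72 h; on this read-out lower numbers stand for stronger inhibition and higher numbers for weaker inhibition:

Compound 1, `Cc1ccc(S(=O)(=O)c2nc3ccccc3nc2N2CCCC2)cc1`, gives > 50000 nM, which is a limit of the assay and not a number.
Compound 2, `COc1ccc(S(=O)(=O)c2nc3ccccc3nc2N2CCCC2)cc1`, gives > 50000 nM, again a limit of the assay rather than a number.
For the measured compounds named here, compound 3, `Cc1ccc(S(=O)(=O)c2nc3ccccc3nc2N2CCCC(O)C2)cc1`, gives 3270 nM, the only number among the three.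

Two of the three values sit at the limit of > 50000 nM in this assay, at which 2 of the 3 values shown sit. The change from compound 1 to compound 2 is methoxy in place of methyl on an aromatic carbon; with both values at the limit, a step that the two limits leave unreadable from compound 1 to compound 2. The change from compound 1 to compound 3 is 3-hydroxypiperidin-1-yl in place of pyrrolidin-1-yl on an aromatic carbon, and here the step is readable: an at least 15-fold lower number from compound 1 to compound 3 (1.18 log units; beyond the scatter).

Compound 4, `COc1ccc(S(=O)(=O)c2nc3ccccc3nc2N2CCCC(O)C2)cc1`, has not yet been measured. It differs from compound 3 by methoxy in place of methyl on an aromatic carbon, the same change as from compound 1 to compound 2, placed identically. That earlier step could not be sized, so the expectation rests on compound 3 alone and on the lack of any visible effect of the change: the step from compound 3 to compound 4 is expected to be a 1.1-fold higher number from compound 3 to compound 4 (0.03 log units; within the scatter). In this assay compound 4 is estimated at 3500 nM, with a likely range from 1200 nM to 10000 nM.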

Compound 4, half-maximal inhibitory concentration: 3520 nM
For compound 4 the middle estimate is 1.0-fold (0.00 log units) below the measured one; the range from low to high includes it.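

In this assay, 3-hydroxypiperidin-1-yl in place of pyrrolidin-1-yl carries over from the 4-methylphenyl compounds to the 4-methoxyphenyl compounds, with an at least 14-fold lower number from compound 2 to compound 4 (1.15 log units; beyond the scatter), and the two cases read together as follows: the same change on two cores in this assay, an at least 15-fold lower number (1.18 log units; beyond the scatter) from compound 1 to compound 3 and an at least 14-fold lower number (1.15 log units; beyond the scatter) from compound 2 to compound 4; the limit leaves it open whether they differ. Compound 2 gives > 50000 nM and this is a limit of the assay and not a number, so the result shows the same direction on two cores but gives no exact size for either step. Methoxy in place of methyl shows no change beyond the scatter among the 3-hydroxypiperidin-1-yl compounds, with a 1.1-fold higher number from compound 3 to compound 4 (0.03 log units; within the scatter), and two cores are too few to promise the same gain on any other core.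

This change alters the ring and adds a hydroxyl in a single step, and the compounds shown do not separate those two parts. A plain piperidin-1-yl group, or an amine in place of the hydroxyl, would be needed to tell how much each part contributes.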